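From Ethynyl to Acetyl at the Assay Limit

The source may hold more compounds than are shown below. What is called first, only, known or untested is meant among the compounds shown, and "the series" means these compounds.

In a functional assay on HCT-116 cells (Homo sapiens) for cytotoxicity, read by scintillation counting and thymidine incorporation, with a stated time of 72 h (on this read-out higher numbers stand for weaker inhibition and lower numbers for stronger inhibition), compound 1 `C#CC=C(c1cc(OC)cc(OC)c1)c1ccc(OC)c(OC)c1` gives > 10000 nM, which is a limit of the assay and not a number. Two related compounds do give numbers. Compound 2 `CCOc1cc(C(=CC#N)c2ccc(N(C)C)cc2)ccc1OC` reads 31 nM, and compound 3 `COc1cccc(C(=CC#N)c2ccc(OC)c(OC)c2)c1` reads 310 nM.

Compound 4 `COc1cc(OC)cc(C(=CC(C)=O)c2ccc(OC)c(OC)c2)c1` keeps the core of compound 1 and makes one change: acetyl in place of ethynyl on a double-bonded chain carbon bound to a double-bonded chain carbon. This places acetyl in place of ethynyl on a double-bonded chain carbon bound to a double-bonded chain carbon.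

Within the data shown here, no measured pair isolates this change, so any forecast remains loose. Compound 3, at 310 nM, shows that a related structure can give a number in this assay, so a measurable value for compound 4 is plausible. A modest shift toward stronger inhibition is expected, with the estimated change being an at least 2.5-fold lower number from compound 1 to compound 4 (0.39 log units; beyond the scatter). The result could still be only a limit. For compound 4 the expected value in this assay is 4000 nM, within an estimated range of 600 nM to 20000 nM.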

Compound 4, half-maximal inhibitory concentration: > 10000 nM
Compound 4 was reported as a limit (the forecaster's own chance of this, stated with the estimate: 40%); middle value at least 2.5-fold (0.39 log units) from the limit.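

Among these compounds, compound 4, like compound 1, is reported only as a limit, and no step between the two can be read because neither gives a number: the limit of > 10000 nM in this assay, at which 2 of the 4 values shown sit. The compounds shown leave open whether acetyl in place of ethynyl changes inhibition at all, and in which direction.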